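This account rests on a few compounds, and the source may have more. Where it says the series, first, only, none or still open, it means among the compounds named here.

Measured compounds in a functional assay on MCF7 cells (Homo sapiens) for cytotoxicity, read by MTT assay, with a stated time of 48 h; a higher number here means a weaker inhibitor, a lower number a stronger inhibitor:
compound 1 `CCCCCCCCNC(=O)[C@@H](NC(=O)c1ccccc1)[C@@H](C)O` gives 111000 nM;
compound 2 `CCCCCCCCCCCCCCNC(=O)[C@@H](NC(=O)c1ccccc1)[C@@H](C)O` gives 24800 nM;
compound 3 `CCCCCCCCCCCCCCCCCCNC(=O)[C@@H](NC(=O)c1ccccc1)[C@@H](C)O` gives 31800 nM.

Compound 3 holds the second highest of the three numbers: its nearest neighbour is compound 2, and that gap is within the scatter, as a 1.3-fold higher number from compound 2 to compound 3 (0.11 log units; within the scatter) shows; its furthest is compound 1, with a 3.5-fold lower number from compound 1 to compound 3 (0.54 log units; beyond the scatter) beyond the scatter. The chain steps a 4.5-fold lower number from compound 1 to compound 2 (0.65 log units; beyond the scatter) and a 3.5-fold lower number from compound 1 to compound 3 (0.54 log units; beyond the scatter) are modest.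

Compound 4 `CCCCCCCCCCCCCCCCCCNC(=O)[C@@H](NS(=O)(=O)c1cccs1)[C@@H](C)O` differs from compound 3 by (thiophen-2-yl)sulfonyl in place of benzoyl on an amine nitrogen. For the measured compounds named here, none of the measured steps touches this part of the molecule; all three concern only the chain, so there is no precedent for the change. The expectation is therefore a step of no particular direction beyond the scatter, a 1.0-fold higher number from compound 3 to compound 4 (0.00 log units; within the scatter), with a wide range. Compound 4 is estimated at 32000 nM, between 8000 nM and 130000 nM.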

Compound 4, half-maximal inhibitory concentration: > 200000 nM
Compound 4 ended at the assay's limit (the forecaster's own chance of this, stated with the estimate: 10%); at least 6.2-fold (0.79 log units) between middle value and limit.
By their numbers in this assay, from the lowest: compounds 2 and 3 (each within the scatter of the next); then compound 1. At a limit, above all of these: compound 4.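

The group on the amine nitrogen, untouched by the chain steps, also moves the read-out: with (thiophen-2-yl)sulfonyl in place of benzoyl, this assay shows an at least 6.2-fold higher number from compound 3 to compound 4 (0.79 log units; beyond the scatter), towards a weaker inhibitor. The value of compound 4 is a limit, not a number: the limit of > 200000 nM in this assay, at which 1 of the 4 values shown sits.

Still open, from the compounds shown here alone, is whether the shift belongs to the sulfonyl link or to the thiophene ring; benzenesulfonyl or thiophene-2-carbonyl on the same nitrogen would separate the two. Also open, going by these compounds, is whether the same change behaves alike on the shorter chains of compound 1 and compound 2.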